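Weighing an Unsaturated Ester Against a Saturated Amide

The compounds below may be only part of what the source reports. "The series", "measured", "known", "first", "only" and "open" are said of these compounds alone.

Compound 1 (`CN1CCN(C(=O)/C=C/c2ccncc2-c2ccc3ccccc3c2)CC1`): > 30000 nM
Compound 2 (`O=C(O)[C@@H]1CCCN1C(=O)/C=C/c1ccncc1-c1ccc2ccccc2c1`): "not determined" (no result reported)
Compound 3 (`CNC(=O)CCc1ccncc1-c1ccc2ccccc2c1`): 19300 nM

All three compounds were entered in a functional assay on HCT-116 cells (Homo sapiens) for inhibition, read by MTT assay, with a stated time of 72 h (a lower number here means a stronger inhibitor of growth, a higher number a weaker inhibitor of growth), but the results give little to compare. The entry for compound 1, > 30000 nM, is a limit of the assay and not a number. Compound 2 has no result. For the measured compounds named here, that leaves compound 3 with the only actual number in the set, 19300 nM, so it has no measured neighbour to be ranked against.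

The next compound to be tested is compound 4 `COC(=O)/C=C/c1ccncc1-c1ccc2ccccc2c1`. It carries 2-(methoxycarbonyl)ethenyl in place of the 2-(methylcarbamoyl)ethyl of compound 3, on an aromatic carbon of a six-membered aromatic ring with 1 nitrogen (2-(methoxycarbonyl)ethenyl in place of 2-(methylcarbamoyl)ethyl on an aromatic carbon). Going by the values given here, no two measured compounds differ in just one place, so the data do not show how much such a swap matters in this assay. The expectation is therefore cautious: a small move toward stronger growth inhibition, not far beyond the usual scatter, with a real chance that the result is only a limit. The expected change is a 1.4-fold lower number from compound 3 to compound 4 (0.14 log units; within the scatter) in this assay. Compound 4 is estimated at 14000 nM (expected range 4000 nM to 30000 nM).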

Compound 4, concentration for 50% growth inhibition: 350 nM
The estimate for compound 4 lay 40-fold (1.60 log units) above the measured number; the whole stated range lies above it.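

In this assay, the group on this aromatic carbon, opposite the ring nitrogen and ortho to a large group, proves to matter a great deal: 2-(methoxycarbonyl)ethenyl in place of 2-(methylcarbamoyl)ethyl gives a 55-fold lower number from compound 3 to compound 4 (1.74 log units; beyond the scatter). The earlier compounds shown here could not show this, since no two of them differed in just one place and only compound 3 had an actual number. On the carbonyl carbon of the unsaturated chain, methoxy in place of 4-methylpiperazin-1-yl gives an at least 85-fold lower number from compound 1 to compound 4 (1.93 log units; beyond the scatter), though compound 1 has a limit and not a number, so this size is only a minimum: the limit of > 30000 nM in this assay, at which 1 of the 4 values shown sits.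

The step from compound 3 to compound 4 changes the chain's link and its end group together, so the compounds shown leave open how much of the gain belongs to the double bond and how much to the ester; 2-(methoxycarbonyl)ethyl and 2-(methylcarbamoyl)ethenyl would separate the two. They also leave open how a free carboxylic acid on the same chain, or a longer ester chain, would compare with the methyl ester of compound 4.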